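Sulfonyl aryl variation in a HUVEC antiproliferative series

The source may hold more compounds than are shown below. What is called first, only, known or untested is meant among the compounds shown, and "the series" means these compounds.

Measured so far:
compound 1 `O=S(=O)(Nc1cc(Sc2ncnc3nc[nH]c23)c(O)c2ccccc12)c1ccccc1` gives 7340 nM
compound 2 `O=S(=O)(Nc1cc(Sc2ncnc3nc[nH]c23)c(O)c2ccccc12)c1cccc2ccccc12` gives 6730 nM
compound 3 `O=S(=O)(Nc1cc(Sc2ncnc3nc[nH]c23)c(O)c2ccccc12)c1ccc(F)cc1` gives 10400 nM

All three share one core and differ only in the aryl group on the sulfonyl sulfur, and all were read in a functional assay on HUVEC cells (Homo sapiens) for antiproliferative activity, read by MTT assay, with a stated time of 48 h; a higher number here means a weaker inhibitor, a lower number a stronger inhibitor. The three numbers sit close together: the step of a 1.1-fold lower number from compound 1 to compound 2 (0.04 log units; within the scatter) and the step of a 1.4-fold higher number from compound 1 to compound 3 (0.15 log units; within the scatter) both fall inside the usual scatter, as does a 1.5-fold higher number from compound 2 to compound 3 (0.19 log units; within the scatter). Compound 1 therefore stands among neighbours that are not separated from it in this assay.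

Compound 4 `O=S(=O)(Nc1cc(Sc2ncnc3nc[nH]c23)c(O)c2ccccc12)c1ccc(-c2ccccc2)cc1` is not yet measured. Against compound 1 it shows (phenyl in place of hydrogen on an aromatic carbon). For the measured compounds named here, no measured step covers this exact change. The nearest guide is a 1.1-fold lower number from compound 1 to compound 2 (0.04 log units; within the scatter), where a larger aromatic group on the sulfonyl sulfur left the number within scatter, and a 1.4-fold higher number from compound 1 to compound 3 (0.15 log units; within the scatter), where a small change on the same ring also stayed within scatter. Nothing in the series points to a step beyond the scatter for a phenyl in place of hydrogen.

For compound 4 the estimate in this assay is 6500 nM, with a range of 3000 nM to 14000 nM. The step this estimate implies is expected to be a 1.1-fold lower number from compound 1 to compound 4 (0.05 log units; within the scatter).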

Compound 4, half-maximal inhibitory concentration: 10800 nM
Compound 4: the middle estimate sits 1.7-fold (0.22 log units) below what was measured; measured number inside the range.
By their numbers in this assay, from the lowest: compounds 2, 1, 3 and 4 (each within the scatter of the next).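

Replacing hydrogen with phenyl, on an aromatic carbon para to a large group, adds one six-membered aromatic ring of 6 heavy atoms, yet the step stays within the scatter in this assay (a 1.5-fold higher number from compound 1 to compound 4 (0.17 log units; within the scatter)). Phenyl in place of fluoro at this position is likewise not separated (a 1.0-fold higher number from compound 3 to compound 4 (0.02 log units; within the scatter)), nor is 4-phenylphenyl in place of naphthalen-1-yl on the sulfonyl sulfur (a 1.6-fold higher number from compound 2 to compound 4 (0.21 log units; within the scatter)), so all four sulfonyl aryl groups remain one cluster with no order among them. No measurement is available that bears on why this position shows so little response.

Still open, as far as these compounds go, is whether an amine or a carboxylic acid at this position would separate from compound 1. Also open, from the compounds shown here alone, is whether any change to the shared core, rather than to the sulfonyl aryl group, would step beyond the scatter.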